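Amide nitrogen substituent series: cyclopentyl to benzyl

The source may report more compounds than this note shows. Statements on the series, on what has been measured and on what is new or still open speak of the compounds shown alone.

Compound 1 `CCCNC(=O)CC1CCc2cc(OC)c(OC)cc21`, compound 2 `CCCCNC(=O)CC1CCc2cc(OC)c(OC)cc21` and compound 3 `COc1cc2c(cc1OC)C(CC(=O)NC1CCCC1)CC2` share one core and differ only in the group on the amide-type nitrogen. In a functional assay on the whole organism (strain Wistar) for inhibition, with Rattus norvegicus as the target, read by paw edema, with stated times of 60 min and 1 h, at a dose of 100 mg/kg by the oral route (on this read-out higher numbers stand for more inhibition at the one dose given (going by the name of the read-out) and lower numbers for less inhibition), compound 1 gives 18.8%, compound 2 gives 31.3% and compound 3 gives 40.6%. Compound 3 stands highest of the three numbers shown; its gap to compound 2 is within the scatter, its gap to compound 1 beyond it. The measured steps are a number 12.5 percentage points higher from compound 1 to compound 2 (beyond the scatter), a number 21.8 percentage points higher from compound 1 to compound 3 (beyond the scatter) and a number 9.3 percentage points higher from compound 2 to compound 3 (within the scatter).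

Compound 4 `COc1cc2c(cc1OC)C(CC(=O)NCc1ccccc1)CC2` carries the change (benzyl in place of cyclopentyl on an amide-type nitrogen). For the measured compounds named here, the steps that bear on it are the two that also replace the group on the amide-type nitrogen, a number 21.8 percentage points higher from compound 1 to compound 3 (beyond the scatter) and a number 9.3 percentage points higher from compound 2 to compound 3 (within the scatter); both ran towards cyclopentyl, and no measured step involves benzyl. The expectation for compound 4 therefore rests on compound 3 at 40.6% and leaves the direction open. Compound 4 is expected to give about 45%, within 28% to 62%. The expected step is a number 4.4 percentage points higher from compound 3 to compound 4 (within the scatter), none beyond the scatter.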

Compound 4, a percentage reported as inhibition, in the whole organism at one dose (the size of the read-out at that dose, not a potency): 18.8%
The estimate for compound 4 lay 26.2 percentage points above the measured number; the measured number lies below the stated range.
By their numbers in this assay, from the lowest: compounds 1 and 4 (each within the scatter of the next); then compounds 2 and 3 (each within the scatter of the next).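

Benzyl is the first change at this position to lower the number: in this assay it gives a number 21.8 percentage points lower from compound 3 to compound 4 (beyond the scatter) and a number 12.5 percentage points lower from compound 2 to compound 4 (beyond the scatter), while no change at the digits printed from compound 1 to compound 4 (within the scatter) places it level with the propyl amide. The rise from propyl through butyl to cyclopentyl therefore does not carry on to benzyl, and compound 4 goes against any reading that more heavy atoms on the amide-type nitrogen give a higher number. Nothing available bears on why this substituent gives the lower number.

Still open, going by these compounds, is whether the drop goes with the aromatic ring or with the ring's attachment through a single chain carbon. A cyclohexylmethyl or a phenethyl group on the amide-type nitrogen would separate these, and a directly attached phenyl would show whether the aromatic ring alone gives the same number.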